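A few compounds are considered here, and "the series" means these few. Any claim that something is new, unique, unknown or untested is made for them only; others in the source may bear on it.

Measured compounds:
- compound 1, `Cc1ccc(NC2=C(Cl)C(=O)c3ncncc3C2=O)cc1C`, 3730 nM in a functional assay on Col2 cells (Homo sapiens) for cytotoxicity; a higher number here means a weaker inhibitor, a lower number a stronger inhibitor
- compound 2, `CCOc1ccccc1/N=C1/C(=O)c2cncnc2C(O)=C1Cl`, 730 nM in this assay

Of the two numbers in hand, compound 2 holds the lower one; compound 1 gives a higher number, and that gap lies beyond the usual scatter. For the measured compounds named here, no step between compounds differing in one place has been measured, so the size of a single change is not yet calibrated.

Compound 3, `Cc1ccccc1/N=C1/C(=O)c2cncnc2C(O)=C1Cl`, is the next to be measured. Its structure differs from compound 2 by methyl in place of ethoxy on an aromatic carbon, with the rest of the core of compound 2 unchanged. Going by the values given here, with no step of this kind yet measured, the expectation rests only on compound 2 and its value, and a modest movement toward a weaker number, or none beyond the scatter, is the working guess. The step from compound 2 to compound 3 is expected to be a 1.6-fold higher number from compound 2 to compound 3 (0.22 log units; within the scatter). Compound 3 is therefore estimated at 1200 nM, in the range 400 nM to 3500 nM.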

Compound 3, half-maximal inhibitory concentration: 3770 nM
The estimate for compound 3 lay 3.1-fold (0.50 log units) below the measured number, outside the stated range (above it).
By their numbers in this assay, from the lowest: compound 2; then compounds 1 and 3 (each within the scatter of the next).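

In this assay the series now has its first calibrated single change: a 5.2-fold higher number from compound 2 to compound 3 (0.71 log units; beyond the scatter), with methyl in place of ethoxy on an aromatic carbon, ortho to a large group. The step lies beyond the scatter, so this position is not indifferent to its substituent, and among these two compounds ethoxy goes with the lower number. No measurement here accounts for the size of the step.

The compounds shown do not separate the contribution of the ether oxygen from that of the chain, and a methoxy or hydroxy group at this position would bear directly on that question. From the compounds shown here alone, it also remains open whether a longer chain such as propoxy or butoxy, or an amine in the same place, would extend or reverse the trend.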